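This account rests on a few compounds, and the source may have more. Where it says the series, first, only, none or still open, it means among the compounds named here.

In an ADME assay on the whole organism (Rattus norvegicus) for pharmacokinetics, using cassette dosing, at a dose of 1 mg/kg by the oral route (a lower number here means that a smaller share of the oral dose reaches the circulation, a higher number that a larger share of the oral dose reaches the circulation), three compounds have been measured so far. Compound 1 `Cc1cc(/N=c2\[nH]c(=O)n(C[C@H](C)C(=O)O)c(=O)n2Cc2ccc(Cl)cc2)ccc1OC(C)C` stands highest at 102%, and its distance from each of the other two lies beyond the scatter. Compound 3 `C[C@@H](Cn1c(=O)[nH]/c(=N\c2ccc(Oc3cccc(F)n3)cc2)n(Cc2ccc(Cl)cc2)c1=O)C(=O)O` follows at 60%, and compound 2 `C[C@@H](Cn1c(=O)[nH]/c(=N\c2ccc(Oc3nccs3)cc2)n(Cc2ccc(Cl)cc2)c1=O)C(=O)O` lies lowest at 41.4%. Compound 4 `CC(C)Oc1ccc(/N=c2\[nH]c(=O)n(C[C@H](C)C(=O)O)c(=O)n2Cc2ccc(Cl)cc2)cc1Cl` has not yet been measured in this assay. It differs from compound 1 in a single substituent: chloro in place of methyl on an aromatic carbon. This places chloro in place of methyl on an aromatic carbon, ortho to an isopropoxy group.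

Among the compounds with values here, the only measured step between two close relatives is a number 18.6 percentage points higher from compound 2 to compound 3 (beyond the scatter). That modest step concerns a different group, so it bears on the present change only loosely, as a rough guide to the size a single substitution can produce in this series. Within the data shown here, no measured pair shows chloro in place of methyl. With compound 1 at 102%, there is more room for a fall than for a rise, so a small decrease is expected, if any change appears at all. The expected outcome is a number 14 percentage points lower from compound 1 to compound 4 (beyond the scatter). For compound 4 the estimated value is 88%, with an expected range from 60% to 112%.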

Compound 4, oral bioavailability: 82.4%
For compound 4 the middle estimate is 5.6 percentage points above the measured one; low and high end bracket the measured number.
By their numbers in this assay, from the lowest: compound 2; then compound 3; then compound 4; then compound 1.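

In this assay the swap of methyl for chloro gives a number 19.6 percentage points lower from compound 1 to compound 4 (beyond the scatter) and thus shows that this aromatic carbon, ortho to an isopropoxy group, is a place where exchanging one heavy atom for another can alter the share of the oral dose that reaches the circulation. The earlier compounds shown here offered only a number 18.6 percentage points higher from compound 2 to compound 3 (beyond the scatter) at a different group, and this second step, also modest, extends that observation to a new position while compound 4 still stands at 82.4% in this assay and remains well within the upper part of the values seen so far. No measurement in hand bears on the origin of this step.

From the compounds shown here alone, what plain hydrogen, a methoxy group or a nitrile would give on this same aromatic carbon stays open, and two substituents alone set no trend for the position. Also open, going by these compounds, is whether the step from methyl to chloro would keep its size if the isopropoxy group gave way to a longer chain or an amine.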